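A few compounds are considered here, and "the series" means these few. Any claim that something is new, unique, unknown or untested is made for them only; others in the source may bear on it.

Notes on the series. Compound 1 `CC(C)C[C@H](N)CN(C(=O)[C@@H]1C[C@H]1c1ccccc1)c1ccc(-c2ccncc2)cc1` gives, in a functional assay for agonist activity at G protein-coupled receptor 88 (Homo sapiens), read by HTRF and cAMP accumulation (a higher number here means that more compound is needed for the effect, a lower number that less compound is needed), a value of 13000 nM. Compound 2 `CC(C)C[C@H](N)CN(C(=O)[C@@H]1C[C@H]1c1ccccc1)c1ccc(-c2ccsc2)cc1` gives 1200 nM, and compound 3 `Cc1cccc(-c2ccc(N(C[C@@H](N)CC(C)C)C(=O)[C@@H]3C[C@H]3c3ccccc3)cc2)c1` gives 1200 nM. The steps to the two lower numbers were an 11-fold lower number from compound 1 to compound 2 (1.03 log units; beyond the scatter) and an 11-fold lower number from compound 1 to compound 3 (1.03 log units; beyond the scatter), while no change at the digits printed from compound 2 to compound 3 (within the scatter). Within the data shown here, compound 3 thus stands level with compound 2 and is one of the two lowest numbers of the three measured, with compound 1 as the only distant member.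

Compound 4 `CC(C)C[C@H](N)CN(C(=O)[C@@H]1C[C@H]1c1ccccc1)c1ccc(-c2cccc(F)c2)cc1` differs from compound 3 by fluoro in place of methyl on an aromatic carbon, on an aromatic carbon of a six-membered aromatic ring of carbon only, meta to a large group. Among the measured compounds shown here, no measured step tests methyl against fluoro; the nearest guidance is that two different groups at this ring position gave no change at the digits printed from compound 2 to compound 3 (within the scatter), so the position appears to accept variation once the pyridin-4-yl is gone. A step within the scatter, or only slightly beyond it, is therefore expected, with no clear direction; the expected step is a 1.3-fold higher number from compound 3 to compound 4 (0.10 log units; within the scatter). Compound 4 is estimated at 1500 nM, within a range of 500 nM to 4500 nM.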

Compound 4, half-maximal effective concentration: 2100 nM
Compound 4: the middle estimate sits 1.4-fold (0.15 log units) below what was measured, within the range that was stated.
By their numbers in this assay, from the lowest: compounds 2, 3 and 4 (each within the scatter of the next); then compound 1.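

Notes on the result. In this assay, among these compounds, fluoro and methyl are compared directly for the first time on this six-membered aromatic ring of carbon only, meta to a large group, and the exchange gives a 1.8-fold higher number from compound 3 to compound 4 (0.24 log units; within the scatter) and does not separate the two compounds. The 3-fluorophenyl group likewise gives a 1.8-fold higher number from compound 2 to compound 4 (0.24 log units; within the scatter) against thiophen-3-yl but a 6.2-fold lower number from compound 1 to compound 4 (0.79 log units; beyond the scatter) against pyridin-4-yl, so three different groups now lie within the scatter of one another and pyridin-4-yl alone stands apart. Nothing at hand accounts for these numbers.

On these data alone, whether an amine, a carboxylic acid or a longer chain in place of the fluoro would stay within the scatter of compound 4 remains open. Also open, as far as these compounds go, is how an unsubstituted phenyl would compare with these groups, and whether the same pattern holds when the rest of the shared core changes.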